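The source may hold more compounds than are shown below. What is called first, only, known or untested is meant among the compounds shown, and "the series" means these compounds.

Measured so far:
Compound 1 `Cn1c(/C=C/C(=O)c2ccc[nH]2)cc(Br)c1Br`: 730 nM
Compound 2 `O=C(/C=C/c1cc(Br)c(Br)[nH]1)c1ccc[nH]1`: 500 nM
Compound 3 `O=c1cc(-c2cc(Br)c(Br)[nH]2)oc2ccccc12`: 410 nM

All three values come from a functional assay on PA-1 cells (Homo sapiens) for cytotoxicity, read by MTT assay, with stated times of 6 h and 48 h; a lower number here means a stronger inhibitor, a higher number a weaker inhibitor. The three numbers lie within the usual scatter of one another, so no order among them is claimed. Going by the values given here, the one change measured directly is methyl in place of hydrogen on an aromatic nitrogen, which gives a 1.5-fold higher number from compound 2 to compound 1 (0.16 log units; within the scatter). How the core of compound 3 differs from the core of compound 2 is not broken down here.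

Compound 4 `Cn1c(-c2cc(=O)c3ccccc3o2)cc(Br)c1Br` is not yet measured. It differs from compound 3 by methyl in place of hydrogen on an aromatic nitrogen. The surroundings of the place differ in wording: in compound 3 the nitrogen sits next to the ring atom that bears a large group, whereas in compound 2 it sits next to the ring atom that bears a group of 9 heavy atoms, so this is the same kind of change, not the same one. Because the matching step gave a 1.5-fold higher number from compound 2 to compound 1 (0.16 log units; within the scatter), the step from compound 3 to compound 4 in this assay is expected to be a 1.5-fold higher number from compound 3 to compound 4 (0.17 log units; within the scatter), of similar size. Compound 4 is therefore estimated at 600 nM, with a likely range from 280 nM to 1300 nM.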

Compound 4, half-maximal inhibitory concentration: 600 nM
Beside the measured number, compound 4's estimate shows no gap at the digits printed; measured number inside the range.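

In this assay, methyl in place of hydrogen on an aromatic nitrogen gives a 1.5-fold higher number from compound 3 to compound 4 (0.17 log units; within the scatter). Set beside the earlier step, the change carries from one core to the other with no difference that can be told apart: the same change on two cores in this assay, a 1.5-fold higher number (0.16 log units; within the scatter) from compound 2 to compound 1 and a 1.5-fold higher number (0.17 log units; within the scatter) from compound 3 to compound 4, 1.0-fold (0.00 log units) apart, within the scatter of two such steps. Going by these compounds alone, each step lies within the scatter, however, so this shows only that the change left the number without a clear shift on these two cores, not that it has a real effect of fixed size or that the match would hold on any other core.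

The compounds shown leave open how a longer chain such as ethyl, or a benzyl group, would behave on that nitrogen. They also leave open what an amine or a carboxylic acid would do there.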